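Shortening the alkyl chain on a nucleoside core

The source may hold more compounds than are shown below. What is called first, only, known or untested is meant among the compounds shown, and "the series" means these compounds.

Compound 1 `CCCCCCc1cn([C@H]2C[C@H](O)[C@@H](CO)O2)c(=O)[nH]c1=O`: 173 ug/mL
Compound 2 `CCCCCc1cn([C@H]2C[C@H](O)[C@@H](CO)O2)c(=O)[nH]c1=O`: 328 ug/mL

Of the compounds shown here, two have been measured in a functional assay on Raji cells (Homo sapiens); a lower number here means a stronger inhibitor, a higher number a weaker inhibitor. Compound 1 gives 173 ug/mL and compound 2 gives 328 ug/mL; the two numbers lie within the usual scatter of each other, so compound 2 cannot be told apart from compound 1 on this evidence. The next compound, compound 3 `CCCc1cn([C@H]2C[C@H](O)[C@@H](CO)O2)c(=O)[nH]c1=O`, continues the same series with a shorter chain. Compared with compound 2 the change is hydrogen in place of ethyl on a saturated chain carbon, three bonds along the chain from an aromatic carbon.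

Within the data shown here, only one measured step bears on this change: a 1.9-fold higher number from compound 1 to compound 2 (0.28 log units; within the scatter), where one carbon was taken off the same chain. Among the measured compounds shown here, that step did not exceed the scatter, so the only guide is a small, uncertain drift toward a higher number as the chain gets shorter. Removing two more carbons is expected to continue that drift, giving a 1.7-fold higher number from compound 2 to compound 3 (0.22 log units; within the scatter). Compound 3 is therefore estimated at 550 ug/mL in this assay, within a range from 220 ug/mL to 1400 ug/mL.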

Compound 3, concentration for 50% inhibition: > 500 ug/mL
Compound 3 was reported as a limit; the forecaster's own chance of this, stated with the estimate: 15%; the middle value does not contradict the limit.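

Compound 3 is reported only as a limit, > 500 ug/mL, in this assay, and not as an exact number. Cutting the pentyl chain to propyl gives an at least 1.5-fold higher number from compound 2 to compound 3 (0.18 log units; that floor lies within the scatter), so this single change cannot yet be separated from ordinary assay noise. Across the full shortening of the chain, the result is an at least 2.8-fold higher number from compound 1 to compound 3 (0.46 log units; beyond the scatter); this is the first gap in the series to clear the scatter, and it gives evidence that the propyl chain is a weaker choice at this position than the longest chain shown, which the one-carbon step could not establish.

Going by these compounds, the true size of the loss stays open, as the reading for compound 3 gives only a bound: the limit of > 500 ug/mL in this assay, at which 1 of the 3 values shown sits. Also open, on these data alone, is whether a longer chain, or an amine or a carboxylic acid in place of the chain, would bring the number down in this assay.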